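The compounds below may be only part of what the source reports. "The series", "measured", "known", "first", "only" and "open" are said of these compounds alone.

Numbers in an assay on CHO cells for displacement of a labelled ligand from Neuronal acetylcholine receptor; alpha3/alpha6/beta2/beta3 (Homo sapiens), read by scintillation counting (on this read-out higher numbers stand for weaker inhibition and lower numbers for stronger inhibition), for the measured compounds:

compound 1, `CCCC(=O)N1CC2CC(C1)N2`: 350 nM
compound 2, `O=C(C1CCC1)N1CC2CC(C1)N2`: 240 nM

Among the compounds with values here, compound 2 is one of only two compounds with a number in this assay; its sole point of comparison is compound 1, and the step of a 1.5-fold lower number from compound 1 to compound 2 (0.16 log units; within the scatter) stays within the scatter, so the two compounds are not separated by the data at hand.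

Compound 3, `O=C([C@H]1C[C@H]1F)N1CC2CC(C1)N2`, has not been measured. It differs from compound 2 in one place: 2-fluorocyclopropyl in place of cyclobutyl on a carbonyl carbon. Within the data shown here, the one measured step that bears on this position is the exchange of the group on the carbonyl carbon from compound 1 to compound 2, a 1.5-fold lower number from compound 1 to compound 2 (0.16 log units; within the scatter), which did not move the number beyond the scatter. Among the measured compounds shown here, nothing speaks to a fluorinated three-membered ring in particular, so no direction can be read from the data; on the strength of the single step available, no step beyond the scatter is expected in this assay.

Compound 3 is therefore expected to land near compound 2, at 280 nM, with a range from 110 nM to 700 nM, meaning an expected step of a 1.2-fold higher number from compound 2 to compound 3 (0.07 log units; within the scatter).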

Compound 3, inhibition constant: 27 nM
Compound 3: middle estimate off by 10-fold (1.02 log units), on the high side; the whole stated range lies above it.
By their numbers in this assay, from the lowest: compound 3; then compounds 2 and 1 (each within the scatter of the next).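

In this assay, the group on the carbonyl carbon can move the number well beyond the scatter, as shown by 2-fluorocyclopropyl in place of cyclobutyl (an 8.9-fold lower number from compound 2 to compound 3 (0.95 log units; beyond the scatter)) and 2-fluorocyclopropyl in place of propyl (a 13-fold lower number from compound 1 to compound 3 (1.11 log units; beyond the scatter)), whereas the earlier exchange of propyl for cyclobutyl stayed within it (a 1.5-fold lower number from compound 1 to compound 2 (0.16 log units; within the scatter)). Cyclobutyl and 2-fluorocyclopropyl have the same heavy-atom count and neither has a hydrogen-bond donor or acceptor, so these counts do not distinguish the two groups, although the step between them is beyond the scatter. No measurement shown here gives a reason for the step.

The exchange from cyclobutyl to 2-fluorocyclopropyl changes the ring size, adds fluorine and introduces defined stereocentres all at once, so the compounds shown do not divide the step among these changes. A plain cyclopropyl group, a 2-fluorocyclobutyl group and the opposite stereoisomer of 2-fluorocyclopropyl on the same carbonyl carbon would each bear on that open question.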